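The source may report more compounds than this note shows. Statements on the series, on what has been measured and on what is new or still open speak of the compounds shown alone.

Compound 1 `CCCCCCCCCCS(=O)(=O)/C=C/c1ccc(O)c(O)c1` gives 6800 nM in a functional assay, read by fluorescence and spectrophotometry, with a stated time of 1 h (on this read-out higher numbers stand for an effect only at larger amounts of compound and lower numbers for an effect already at smaller amounts), the second highest of the three numbers. Compound 3 `O=S(=O)(/C=C/c1ccc(O)c(O)c1)CCCCCCCCO` gives 6700 nM, and the step of a 1.0-fold lower number from compound 1 to compound 3 (0.01 log units; within the scatter) lies within the scatter. Compound 2 `O=S(=O)(/C=C/c1ccc(O)c(O)c1)CC1CCCN1` gives 13800 nM, a higher number than that of compound 1 and beyond the scatter. Compound 4 `O=S(=O)(/C=C/c1ccc(O)c(O)c1)CCCC1CCCCC1` is not yet measured and differs from compound 1 by cyclohexyl in place of heptyl on a saturated chain carbon, three bonds along the chain from a sulfonyl sulfur. Among the compounds with values here, no measured step alters the chain at this place; the only measured step on the chain, from compound 1 to compound 3, stayed within the scatter, and no compound shows a ring on the chain. For compound 4 no step beyond the scatter is therefore expected, the estimated step being a 1.0-fold higher number from compound 1 to compound 4 (0.01 log units; within the scatter). Compound 4 is estimated at 7000 nM, with a range from 3000 nM to 16000 nM.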

Compound 4, half-maximal effective concentration: 7900 nM
Beside the measured number, compound 4's estimate is 1.1-fold (0.05 log units) below it, and the stated range covers the measured number.
By their numbers in this assay, from the lowest: compounds 3, 1, 4 and 2 (each within the scatter of the next, the first and the last beyond it).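

In this assay, cyclohexyl in place of heptyl at this place, three bonds along the chain from a sulfonyl sulfur, gives a 1.2-fold higher number from compound 1 to compound 4 (0.07 log units; within the scatter), so a six-membered non-aromatic ring here leaves the number within the scatter. Cyclohexyl in place of 5-hydroxypentyl reads the same, a 1.2-fold higher number from compound 3 to compound 4 (0.07 log units; within the scatter), and compounds 1, 3 and 4 therefore sit together despite their different chain ends. Nothing available accounts for this flatness.

From the compounds shown here alone, whether an amine or a carboxylic acid at this place, or a phenyl ring in place of cyclohexyl, would move the number beyond the scatter stays open. A longer chain is equally untested here.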